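A (1,3-thiazol-2-yl)amino swap in a narrow set

The source may hold more compounds than are shown below. What is called first, only, known or untested is meant among the compounds shown, and "the series" means these compounds.

In a functional assay on U-937 cells (Homo sapiens) for cytotoxicity, read by MTT assay, with a stated time of 3 days (a lower number here means a stronger inhibitor, a higher number a weaker inhibitor), compound 1 `N#Cc1c(O)nc(SCc2nc3ccccc3[nH]2)nc1-c1ccccc1` gives 3.28 nM, compound 2 `N#Cc1c(Nc2ccccc2)nc(SCc2nc3ccccc3[nH]2)nc1-c1ccccc1` gives 3.28 nM and compound 3 `CCNc1nc(SCc2nc3ccccc3[nH]2)nc(-c2ccccc2)c1C#N` gives 2.63 nM, so compound 3 stands within the scatter of both others. Compound 4 `N#Cc1c(Nc2nccs2)nc(SCc2nc3ccccc3[nH]2)nc1-c1ccccc1` carries 1,3-thiazol-2-yl in place of ethyl on a nitrogen on an aromatic ring. Among the compounds with values here, the closest precedent is the exchange of ethyl and phenyl on that nitrogen, seen as a 1.2-fold lower number from compound 2 to compound 3 (0.10 log units; within the scatter). The changes from hydroxy also stay small, at no change at the digits printed from compound 1 to compound 2 (within the scatter) and a 1.2-fold lower number from compound 1 to compound 3 (0.10 log units; within the scatter). No shift beyond the scatter is therefore expected, and the estimated step is a 1.1-fold higher number from compound 3 to compound 4 (0.06 log units; within the scatter). The expected value for compound 4 is 3 nM, with an estimated range of 1.3 nM to 7 nM.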

Compound 4, half-maximal inhibitory concentration: 3.8 nM
Beside the measured number, compound 4's estimate is 1.3-fold (0.10 log units) below it; the measured number falls inside the stated range.
By their numbers in this assay, from the lowest: compounds 3, 1, 2 and 4 (each within the scatter of the next).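

On this nitrogen, a five-membered aromatic ring with 2 hetero atoms now joins ethyl and phenyl with only small steps: a 1.4-fold higher number from compound 3 to compound 4 (0.16 log units; within the scatter) and a 1.2-fold higher number from compound 2 to compound 4 (0.06 log units; within the scatter). Set against hydroxy on the aromatic carbon, (1,3-thiazol-2-yl)amino also gives only a 1.2-fold higher number from compound 1 to compound 4 (0.06 log units; within the scatter), so this position has now taken three different amino groups without a step beyond the scatter. No evidence is available to explain this flat response.

On these data alone, whether any group here can move the number beyond the scatter remains open. A carboxylic acid or a longer alkyl chain on this nitrogen would test that.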